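This account rests on a few compounds, and the source may have more. Where it says the series, first, only, none or still open, it means among the compounds named here.

The measured compounds:
Compound 1, `Cn1cc(C(=O)c2ccccc2)cc1/C=C/C(=O)NO`, gives 86% in an assay on isolated protein for inhibition of histone deacetylase HD2 (Zea mays), tested at 30 uM; a higher number here means more inhibition at the concentration tested (going by the name of the read-out), a lower number less inhibition.
Compound 2, `Cn1cc(C(=O)c2ccccc2)cc1CCC(=O)NO`, gives 45%.
Compound 3, `CN(C)c1ccc(C(=O)c2cc(/C=C/C(=O)NO)n(C)c2)cc1`, gives 88%.

Among these three numbers compound 3 stands highest, but its nearest neighbour, compound 1, lies within the scatter of it; only compound 2 sits clearly lower. Among the compounds with values here, the one large step seen, a number 41 percentage points lower from compound 1 to compound 2 (beyond the scatter), came with 2-(hydroxycarbamoyl)ethyl in place of 2-(hydroxycarbamoyl)ethenyl on an aromatic carbon. The other step, a number 2 percentage points higher from compound 1 to compound 3 (within the scatter), came with dimethylamino in place of hydrogen on an aromatic carbon and stayed within the scatter.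

Compound 4, `Cn1cc(C(=O)c2ccc([N+](=O)[O-])cc2)cc1/C=C/C(=O)NO`, has not yet been measured. It differs from compound 3 in one place: nitro in place of dimethylamino on an aromatic carbon. It keeps the 2-(hydroxycarbamoyl)ethenyl group that compound 2 lacks, so the large step does not bear on it. Within the data shown here, the only step that touches this aromatic carbon, a number 2 percentage points higher from compound 1 to compound 3 (within the scatter), lay within the scatter, so no step beyond the scatter is expected in this assay here either. The expected step of a number 4 percentage points lower from compound 3 to compound 4 (within the scatter) is thus estimated to be small. Compound 4 is therefore expected to give about 84%, estimated between 70% and 95%.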

Compound 4, a percentage reported as inhibition, at one concentration (the size of the read-out at that concentration, not a potency): 78%
Estimate against measurement, compound 4: 6 percentage points above; low and high end bracket the measured number.
By their numbers in this assay, from the lowest: compound 2; then compounds 4, 1 and 3 (each within the scatter of the next).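

In this assay, putting nitro in place of dimethylamino on this aromatic carbon, para to a large group, gives a number 10 percentage points lower from compound 3 to compound 4 (within the scatter), and nitro in place of hydrogen gives a number 8 percentage points lower from compound 1 to compound 4 (within the scatter). With the 2-(hydroxycarbamoyl)ethenyl group kept, hydrogen, dimethylamino and nitro at this carbon therefore all leave the read-out within the scatter of one another, so the position has now accepted two quite different groups without a clear step. Nothing available explains why the number stays level here.

On these data alone, it remains open whether a carboxylic acid, a primary amine or a longer chain such as butoxy at this carbon would also stay within the scatter. As far as these compounds go, it is also open whether nitro or dimethylamino would change the number on the 2-(hydroxycarbamoyl)ethyl chain of compound 2, and whether potency would separate compounds that look alike at one concentration.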